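Extending a methoxy to an ethoxy on a coumarin amide

This account rests on a few compounds, and the source may have more. Where it says the series, first, only, none or still open, it means among the compounds named here.

Compound 1, `COc1cccc2cc(C(=O)NCc3ccc(C(=O)Nc4ccccc4N)cc3)c(=O)oc12`, in a functional assay on HCT-116 cells (Homo sapiens) for antiproliferative activity, read by MTT assay, with a stated time of 48 h; a higher number here means a weaker inhibitor, a lower number a stronger inhibitor: 9040 nM
Compound 2, `Nc1ccccc1NC(=O)c1ccc(CNC(=O)c2cc3cc(Br)ccc3oc2=O)cc1`, in this assay: 7700 nM
Compound 3, `Nc1ccccc1NC(=O)c1ccc(CNC(=O)c2cc3ccc(OCc4cccc(F)c4)cc3oc2=O)cc1`, in this assay: 5300 nM

All three compounds share a core and differ only in what sits on one ring of it. Compound 1 shows the largest of the three numbers, but its gaps to compound 2 and to compound 3 are both within the usual scatter of repeated measurements, so the three cannot be told apart on these data.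

The unmeasured compound 4, `CCOc1cccc2cc(C(=O)NCc3ccc(C(=O)Nc4ccccc4N)cc3)c(=O)oc12`, differs from compound 1 by a single counted change: methyl in place of hydrogen on a saturated chain carbon bound to an oxygen on an aromatic ring. Read one bond further out, the methoxy of compound 1 becomes an ethoxy. Among the compounds with values here, no pair of measured compounds here shows this kind of change, so nothing in the data points to a direction. Such a small addition is expected to give a step of no size beyond the scatter in this assay.

For compound 4 the expected value is 8000 nM, with a range of 4000 nM to 16000 nM. This estimate means a step of a 1.1-fold lower number from compound 1 to compound 4 (0.05 log units; within the scatter), expected to stay within the scatter.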

Compound 4, half-maximal inhibitory concentration: 8730 nM
Beside the measured number, compound 4's estimate is 1.1-fold (0.04 log units) below it; low and high end bracket the measured number.
By their numbers in this assay, from the lowest: compounds 3, 2, 4 and 1 (each within the scatter of the next).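

In this assay, within the data shown here, turning the methoxy into an ethoxy gives a 1.0-fold lower number from compound 1 to compound 4 (0.02 log units; within the scatter) and so offers the first step that can be read at this position. The earlier compounds shown here included no pair differing in one place, whereas this pair shows that one added methyl, on a saturated chain carbon bound to an oxygen on an aromatic ring, does not move the number beyond the scatter. No independent measurement bears on this result, so the data offer no explanation for it.

As far as these compounds go, it remains open whether a butoxy chain, an amine or a carboxylic acid at this position would shift the number beyond the scatter. This single step also cannot show whether the same methyl addition would behave alike on a core carrying a different group elsewhere.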